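Difluorophenyl to trifluoromethylphenyl: an analogue awaiting measurement

A few compounds are considered here, and "the series" means these few. Any claim that something is new, unique, unknown or untested is made for them only; others in the source may bear on it.

compound 1 `CN(C(=O)NC(=O)c1ccc(F)c(F)c1)c1nc(C(F)(F)F)c(C(=O)N/N=C/c2ccc(C(F)(F)F)cc2)s1` — 5.93 ug/mL
compound 2 `CNc1nc(C)c(C(=O)N/N=C/c2cccc(C(F)(F)F)c2)s1` — > 100 ug/mL

Within the data shown here, in a functional assay on MCF7 cells (Homo sapiens) for inhibition, read by MTT assay, with a stated time of 72 h (a lower number here means a stronger inhibitor, a higher number a weaker inhibitor), compound 1 gives 5.93 ug/mL, the only number in this set. For compound 2 the assay returns only a limit, > 100 ug/mL. That reading is the limit of > 100 ug/mL in this assay, at which 1 of the 2 values shown sits.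

Compound 3 `CN(C(=O)NC(=O)c1cccc(C(F)(F)F)c1)c1nc(C(F)(F)F)c(C(=O)N/N=C/c2ccc(C(F)(F)F)cc2)s1` differs from compound 1 by 3-(trifluoromethyl)phenyl in place of 3,4-difluorophenyl on a carbonyl carbon. Among the measured compounds shown here, no measured pair shows this change, so nothing fixes its size; the step of a 1.1-fold higher number from compound 1 to compound 3 (0.04 log units; within the scatter) is expected to stay within the scatter, in no clear direction. Compound 3 is therefore estimated at 6.5 ug/mL, with a range from 2.5 ug/mL to 18 ug/mL.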

Compound 3, half-maximal inhibitory concentration: 6.5 ug/mL
Compound 3: middle estimate and measured number agree at the digits printed; low and high end bracket the measured number.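

On a carbonyl carbon whose other neighbour is an amide-type nitrogen, 3-(trifluoromethyl)phenyl in place of 3,4-difluorophenyl gives, in this assay, a 1.1-fold higher number from compound 1 to compound 3 (0.04 log units; within the scatter). Among these compounds, this place therefore takes the group of 10 heavy atoms as well as the one of 8, a tolerance that the earlier compounds could not show, though it rests on this single step. Nothing measured here accounts for this step. The compounds shown leave open how this place responds to a group without an aromatic ring, such as a short alkyl chain, or to a phenyl ring carrying an amine or a carboxylic acid.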